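Swapping a Hydroxyl for Fluorine on the Sulfonyl Sulfur

A few compounds are considered here, and "the series" means these few. Any claim that something is new, unique, unknown or untested is made for them only; others in the source may bear on it.

Three related sulfonamides have been tested in an ADME assay on HEK293 cells (Homo sapiens) for cytotoxicity, read by resazurin assay, with a stated time of 48 h; a lower number here means that less compound is tolerated, a higher number that more compound is tolerated. Compound 1 `O=S(=O)(Nc1ccc2oc(-c3ccccc3)nc2c1)c1ccccc1O` gives 33000 nM in this assay, the lowest of the two numbers available. Compound 2 `COc1ccc(Cl)cc1S(=O)(=O)Nc1ccc(-c2nc3ccccc3o2)cc1` gives 75000 nM in this assay, a difference from compound 1 that lies beyond the usual scatter. For compound 3 `O=S(=O)(Nc1ccc(-c2nc3ccccc3o2)cc1)c1cccc(C(F)(F)F)c1` this assay reports only a limit, > 100000 nM, and not a number (the limit of > 100000 nM in this assay, at which 1 of the 3 values shown sits). For the measured compounds named here, no pair of measured compounds differs in just one place, so no measured single step is available.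

Compound 4 `O=S(=O)(Nc1ccc2oc(-c3ccccc3)nc2c1)c1cccc(F)c1` has not yet been measured. It differs from compound 1 in one place: 3-fluorophenyl in place of 2-hydroxyphenyl on a sulfonyl sulfur. The two numbers sit toward the tolerated end of this assay, and compound 2 with its substituted phenyl on the sulfonyl sulfur gives 75000 nM, so a moderate upward step is expected here, probably near or just beyond the scatter rather than a large one. Compound 4 is expected to give about 60000 nM in this assay, with a plausible range from 25000 nM to 100000 nM. The expected step is a 1.8-fold higher number from compound 1 to compound 4 (0.26 log units; within the scatter).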

Compound 4, half-maximal cytotoxic concentration: 68000 nM
Beside the measured number, compound 4's estimate is 1.1-fold (0.05 log units) below it, within the range that was stated.
By their numbers in this assay, from the lowest: compound 1; then compounds 4 and 2 (each within the scatter of the next). At a limit, above all of these: compound 3.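

For the compounds shown here, compound 1 and compound 4 form the first pair here that differs in one place, so a single change on the sulfonyl sulfur can now be read in this assay (a 2.1-fold higher number from compound 1 to compound 4 (0.31 log units; beyond the scatter)). The step is modest, but it shows that the group at this place can shift the number on an unchanged core. The swap takes away the hydrogen-bond donor and acceptor counted on 2-hydroxyphenyl, yet no measurement shown here ties the step to that loss or to the arrival of fluorine.

With one pair, the effects of removing the hydroxyl and adding fluorine cannot be separated. A plain phenyl on the sulfonyl sulfur, or a phenyl carrying an amine or a carboxylic acid, would show how far this step extends to other groups.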